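The compounds below may be only part of what the source reports. "The series", "measured", "known", "first", "only" and "open" are said of these compounds alone.

Of the compounds shown here, three that share one core have been tested in a functional assay on Ehrlich cells (Mus musculus) for cytotoxicity, read by trypan blue exclusion, with a stated time of 2 h, tested at 50 ug/mL; a lower number here means a weaker effect, a higher number a stronger effect of the compound at the concentration tested. Compound 1 `N#CC1=C(N)N(c2ccc(S(N)(=O)=O)cc2)C2=C(CCCC2)C1/C=C/c1ccccc1` gives 90%. Compound 2 `N#CC1=C(N)N(c2ccc(S(N)(=O)=O)cc2)C2=C(CCCC2)C1c1cccc([N+](=O)[O-])c1` gives 2%, and compound 3 `N#CC1=C(N)N(c2ccc(S(N)(=O)=O)cc2)C2=C(CCCC2)C1c1ccccc1Cl` gives 5%. On these numbers compound 3 stands far from compound 1 and within the usual scatter of compound 2. Compound 4 `Cc1ccc(C2C(C#N)=C(N)N(c3ccc(S(N)(=O)=O)cc3)C3=C2CCCC3)o1` has not yet been measured; it differs from compound 3 by 5-methylfuran-2-yl in place of 2-chlorophenyl on a saturated ring carbon. The measured steps that bear on this change are a number 85 percentage points lower from compound 1 to compound 3 (beyond the scatter) and a number 3 percentage points higher from compound 2 to compound 3 (within the scatter): replacing 2-phenylethenyl by 2-chlorophenyl lowered the number greatly, while exchanging 3-nitrophenyl for 2-chlorophenyl changed it only within the scatter. Since a different aromatic ring again enters, a step of about a number 5 percentage points higher from compound 3 to compound 4 (within the scatter) is expected in this assay, that is, none beyond the scatter. Compound 4 is therefore estimated at 10%, between 0% and 40%.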

Compound 4, a percentage reported as activity, at one concentration (the size of the read-out at that concentration, not a potency): 10%
Compound 4: the middle estimate sits on the measured number at the digits printed, and the stated range covers the measured number.
By their numbers in this assay, from the lowest: compounds 2, 3 and 4 (each within the scatter of the next); then compound 1.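

In this assay, 5-methylfuran-2-yl, a five-membered aromatic ring with 1 hetero atom, sits with the two substituted phenyl groups on this saturated ring carbon: the change gives a number 5 percentage points higher from compound 3 to compound 4 (within the scatter) and a number 8 percentage points higher from compound 2 to compound 4 (within the scatter) as its steps. The gap to the 2-phenylethenyl compound remains, with a number 80 percentage points lower from compound 1 to compound 4 (beyond the scatter) as the step, so among these four compounds the low numbers are not confined to six-membered carbon rings. On these data alone, whether a plain ethyl chain, a longer chain such as 3-phenylpropenyl, or a piperidine ring would keep the high number stays open. Nothing available here explains the gap to compound 1.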